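Purine nucleosides: aryl swap at the six-membered ring

The compounds below may be only part of what the source reports. "The series", "measured", "known", "first", "only" and "open" are said of these compounds alone.

Measured so far:
compound 1, `Cn1cccc1-c1ncnc2c1ncn2C1O[C@H](CO)[C@@H](O)[C@H]1O`, 2000 nM in a functional assay on CCRF-CEM cells (Homo sapiens) for inhibition; a lower number here means a stronger inhibitor, a higher number a weaker inhibitor
compound 2, `OC[C@H]1OC(n2cnc3c(-c4ccc(Cl)cc4)ncnc32)[C@H](O)[C@@H]1O`, 900 nM

For the measured compounds named here, compound 2 holds the lowest of the two numbers; its only neighbour is compound 1, and the step of a 2.2-fold lower number from compound 1 to compound 2 (0.35 log units; beyond the scatter) runs in its favour. Compound 3, `OC[C@H]1OC(n2cnc3c(-c4ccco4)ncnc32)[C@H](O)[C@@H]1O`, is not yet measured. Its change from compound 2 is furan-2-yl in place of 4-chlorophenyl on an aromatic carbon: 4-chlorophenyl leaves and furan-2-yl enters, on an aromatic carbon of a six-membered aromatic ring with 2 nitrogen, part of a fused or bridged system of two rings. Going by the values given here, no measured step exchanges these two groups. Among the compounds with values here, the one step known, a 2.2-fold lower number from compound 1 to compound 2 (0.35 log units; beyond the scatter), shows that a five-membered aromatic ring with 1 hetero atom at this place gave a higher number than 4-chlorophenyl did, so a step back up, modest in size, is expected as a 1.8-fold higher number from compound 2 to compound 3 (0.25 log units; within the scatter). Compound 3 is therefore expected at 1600 nM, within 600 nM to 4500 nM.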

Compound 3, half-maximal inhibitory concentration: 600 nM
Estimate against measurement, compound 3: 2.7-fold (0.43 log units) above; the measured number falls inside the stated range.
By their numbers in this assay, from the lowest: compounds 3 and 2 (each within the scatter of the next); then compound 1.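

In this assay, exchanging 4-chlorophenyl for furan-2-yl on this aromatic carbon gives a 1.5-fold lower number from compound 2 to compound 3 (0.18 log units; within the scatter), so the two groups cannot be told apart here, despite the difference in ring size. Exchanging 1-methyl-1H-pyrrol-2-yl for furan-2-yl gives a 3.3-fold lower number from compound 1 to compound 3 (0.52 log units; beyond the scatter), so two groups that are each a five-membered aromatic ring with 1 hetero atom are separated here, and that ring type alone does not fix the number at this place. Nothing available explains either step.

Furan-2-yl and 1-methyl-1H-pyrrol-2-yl differ in both the ring hetero atom and the methyl group, and the unmethylated 1H-pyrrol-2-yl would be needed to separate the two. From the compounds shown here alone, how far this place tolerates groups other than aromatic rings, such as an amine or a longer alkyl chain, also remains open.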